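Thiophen-3-yl in place of 3-hydroxyphenyl on compound 2

The compounds below may be only part of what the source reports. "The series", "measured", "known", "first", "only" and "open" are said of these compounds alone.

Measured in an assay on isolated protein for inhibition of Amine oxidase [flavin-containing] B (Homo sapiens), read by fluorescence; on this read-out lower numbers stand for stronger inhibition and higher numbers for weaker inhibition:
compound 1 `N#Cc1cccc(/C=C/C(=O)c2cc(O)c(O)c([N+](=O)[O-])c2)c1` gives 60600 nM
compound 2 `O=C(/C=C/c1cccc(O)c1)c1cc(O)c(O)c([N+](=O)[O-])c1` gives 55800 nM
compound 3 `CC(=O)N1N=C(c2cc(O)c(O)c([N+](=O)[O-])c2)CC1c1ccc(C#N)cc1` gives 83200 nM

Compound 2 holds the lowest of the three numbers, yet its gaps to compound 1 and compound 3 stay within the scatter, so nothing separates them. Compound 4 `O=C(/C=C/c1ccsc1)c1cc(O)c(O)c([N+](=O)[O-])c1` differs from compound 2 by thiophen-3-yl in place of 3-hydroxyphenyl on a double-bonded chain carbon bound to a double-bonded chain carbon. Within the data shown here, the only measured step, a 1.1-fold lower number from compound 1 to compound 2 (0.04 log units; within the scatter), swaps a substituent on that same ring and stays within the scatter; no measured step exchanges the ring itself, so the data give no direction for this change. The step of a 1.1-fold higher number from compound 2 to compound 4 (0.03 log units; within the scatter) is therefore expected to stay within the scatter. Compound 4 is estimated at 60000 nM, in the range 20000 nM to 180000 nM.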

Compound 4, half-maximal inhibitory concentration: 42100 nM
For compound 4 the middle estimate is 1.4-fold (0.15 log units) above the measured one, within the range that was stated.
By their numbers in this assay, from the lowest: compounds 4, 2, 1 and 3 (each within the scatter of the next).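

In this assay, among these compounds, the step (a 1.3-fold lower number from compound 2 to compound 4 (0.12 log units; within the scatter)) is the first to exchange the whole ring on this double-bonded chain carbon, not just a substituent on it. Thiophen-3-yl, with its five-membered ring and no hydrogen-bond donor, stands within the scatter of 3-hydroxyphenyl, so neither the six-membered carbon ring nor its hydroxy group is needed to keep this level of inhibition. No evidence on hand bears on this result. The compounds shown leave open whether an amine or a carboxylic acid on the ring, or cyclohexyl in its place, would give a number beyond the scatter.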